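Smaller amine at the ring carbon of the shared core

The source may hold more compounds than are shown below. What is called first, only, known or untested is meant among the compounds shown, and "the series" means these compounds.

Working notes on the series, followed in an assay on isolated protein for displacement of a labelled ligand from melanin-concentrating hormone receptor 1 (Homo sapiens); on this read-out lower numbers stand for stronger inhibition and higher numbers for weaker inhibition. Compound 1 `CCCc1cc(N2CCCCC2)c2cc(NC(=O)/C=C/c3ccc(C(F)(F)F)cc3)ccc2n1` is known in this assay only as a limit: compound 1 gives > 4000 nM, which is a limit of the measurement and not a number. The other measured member, compound 2 `CCCc1cc(N)c2cc(NC(=O)/C=C/c3ccc(CC)cc3)ccc2n1`, gives 1.4 nM in this assay. Where compound 1 stands can therefore be stated only as the limit of > 4000 nM in this assay, at which 1 of the 2 values shown sits; no measured step between two compounds that differ in one place is available, so no step size has been observed directly.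

Compound 3 `CCCc1cc(N(C)C)c2cc(NC(=O)/C=C/c3ccc(C(F)(F)F)cc3)ccc2n1` has not yet been measured in this assay. It differs from compound 1 in a single place: dimethylamino in place of piperidin-1-yl on an aromatic carbon. No shown step covers this change, and the starting point is itself a limit, so the expectation rests on little. The change is expected to move compound 3 toward stronger binding than compound 1, beyond the scatter but not greatly: the step of an at least 2.6-fold lower number from compound 1 to compound 3 (0.42 log units; beyond the scatter) is the estimate. Compound 3 is thus expected at 1500 nM in this assay, with a range from 200 nM to 8000 nM, and a fair chance that only a limit is again reported.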

Compound 3, half-maximal inhibitory concentration: 43 nM
Estimate against measurement, compound 3: 35-fold (1.54 log units) above; the measured number lies below the stated range.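

On the aromatic carbon opposite the ring nitrogen, the amine has a large effect on this assay: dimethylamino in place of piperidin-1-yl gives an at least 93-fold lower number from compound 1 to compound 3 (1.96 log units; beyond the scatter). Among the compounds shown here, this is the first step observed between two compounds that differ in one place, and it shows that, with the trifluoromethyl end of the molecule and the propyl group unchanged, this single group can decide between a measured number in the nanomolar range and a limit. The step has a lower bound but no upper one, since compound 1 is known only as a limit: the limit of > 4000 nM in this assay, at which 1 of the 3 values shown sits.

One pair cannot tell whether the ring, the count of heavy atoms or something else in the amine carries the difference; a pyrrolidin-1-yl or a methylamino group at this place, on the same trifluoromethyl compound, would begin to separate these readings. Compound 2 carries an amino group at this place, but it also has ethyl instead of trifluoromethyl, and it therefore differs from compound 3 in two places and gives no clean comparison.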